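This account rests on a few compounds, and the source may have more. Where it says the series, first, only, none or still open, it means among the compounds named here.

Measured compounds:
compound 1 `CCCCCCCCCCCCNC(=O)[C@@H](NC(=O)c1cccs1)[C@@H](C)O` gives 30400 nM in a functional assay on MCF7 cells (Homo sapiens) for cytotoxicity, read by MTT assay, with a stated time of 48 h; a lower number here means a stronger inhibitor, a higher number a weaker inhibitor;
compound 2 `CCCCCCCCCCCCNC(=O)[C@@H](NC(=O)c1cc2ccccc2o1)[C@@H](C)O` gives 20900 nM;
compound 3 `CCCCCCCCCCCCCCCCCCNC(=O)[C@@H](NC(=O)c1cccs1)[C@@H](C)O` gives 25700 nM.

Compound 4 `CCCCCCCCCCCCCCCCCCNC(=O)[C@@H](NC(=O)c1cc2ccccc2o1)[C@@H](C)O` has not yet been measured. It differs from compound 3 by 1-benzofuran-2-yl in place of thiophen-2-yl on a carbonyl carbon. The same change was already made once, from compound 1 to compound 2: 1-benzofuran-2-yl in place of thiophen-2-yl on a carbonyl carbon, and it gave a 1.5-fold lower number from compound 1 to compound 2 (0.16 log units; within the scatter). The cores of the two pairs differ by hexyl in place of hydrogen on a saturated chain carbon, ten or more bonds along the chain from an amide-type nitrogen, a change that itself gave a 1.2-fold lower number from compound 1 to compound 3 (0.07 log units; within the scatter). Within the data shown here, since the place of the change is the same in both pairs, and the only measured instance of it stayed within the scatter, compound 4 is expected to follow compound 3 closely, with an estimated step of a 1.4-fold lower number from compound 3 to compound 4 (0.15 log units; within the scatter). Compound 4 is therefore estimated at 18000 nM.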

Compound 4, half-maximal inhibitory concentration: 126000 nM
Beside the measured number, compound 4's estimate is 7.0-fold (0.85 log units) below it; the measured number lies above the stated range.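

In this assay, 1-benzofuran-2-yl in place of thiophen-2-yl gave a 4.9-fold higher number from compound 3 to compound 4 (0.69 log units; beyond the scatter), so the change did not carry over from one core to the other: the same change on two cores in this assay, a 1.5-fold lower number (0.16 log units; within the scatter) from compound 1 to compound 2 and a 4.9-fold higher number (0.69 log units; beyond the scatter) from compound 3 to compound 4, 7.1-fold (0.85 log units) apart, beyond the scatter of two such steps. Hexyl in place of hydrogen on the chain gave a 6.0-fold higher number from compound 2 to compound 4 (0.78 log units; beyond the scatter), and this change did not carry over either: the same change on two cores in this assay, a 1.2-fold lower number (0.07 log units; within the scatter) from compound 1 to compound 3 and a 6.0-fold higher number (0.78 log units; beyond the scatter) from compound 2 to compound 4, 7.1-fold (0.85 log units) apart, beyond the scatter of two such steps. Both gaps rest on compound 4 alone, so they show one combination that departs from the earlier steps, not a rule for the series, and they give no reason for it.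

The compounds shown leave open whether a shorter addition to the chain, such as butyl, would bring the same departure. They also leave open whether another group on the carbonyl carbon, such as phenyl or furan-2-yl, would behave like 1-benzofuran-2-yl.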